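This account rests on a few compounds, and the source may have more. Where it says the series, first, only, none or still open, it means among the compounds named here.

- compound 1 `NC1=NC2(CCSCC2)N(OCCCOc2cc(Cl)c(Cl)cc2Cl)C(N)=N1` with 730 nM
- compound 2 `NC1=NC2(CCSCC2)N(OCCCOc2ccccc2Br)C(N)=N1` with 180 nM

In a functional assay on HL-60 cells (Homo sapiens) for antiproliferative activity, read by MTT assay, with a stated time of 72 h (on this read-out higher numbers stand for weaker inhibition and lower numbers for stronger inhibition), compound 2 has the lower of these two numbers. Compound 3 `NC1=NC2(CCSCC2)N(OCCCOc2ccc(Cl)cc2)C(N)=N1` is still unmeasured and has 4-chlorophenyl in place of 2-bromophenyl on an oxygen on a saturated carbon. Going by the values given here, only one measured step bears on this change: a 4.1-fold lower number from compound 1 to compound 2 (0.61 log units; beyond the scatter) came from swapping the group at this same place, and it was modest but beyond the scatter. With so little to go on, a similarly modest move toward a higher number is expected. The estimated change is a 1.7-fold higher number from compound 2 to compound 3 (0.22 log units; within the scatter) in this assay on this basis. Compound 3 is estimated at 300 nM (expected range 100 nM to 900 nM).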

Compound 3, half-maximal inhibitory concentration: 430 nM
Estimate against measurement, compound 3: 1.4-fold (0.16 log units) below; the range from low to high includes it.
By their numbers in this assay, from the lowest: compound 2; then compounds 3 and 1 (each within the scatter of the next).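

In this assay the group on this oxygen clearly matters: 4-chlorophenyl in place of 2-bromophenyl gives a 2.4-fold higher number from compound 2 to compound 3 (0.38 log units; beyond the scatter) and so loses some of the activity. Set against the 2,4,5-trichlorophenyl group, the same 4-chlorophenyl gives a 1.7-fold lower number from compound 1 to compound 3 (0.23 log units; within the scatter) and cannot be told apart from it. Compound 2 thus stands apart from both, and no measurement here explains why.

Still open, as far as these compounds go, is whether the bromine or its place on the ring sets compound 2 apart, which 4-bromophenyl could help to tell. From the compounds shown here alone, how an amine or a carboxylic acid in place of the phenyl ring would read is also open.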